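The source may report more compounds than this note shows. Statements on the series, on what has been measured and on what is new or still open speak of the compounds shown alone.

Measured so far in a functional assay on LNCaP cells (Homo sapiens) for antiproliferative activity; a lower number here means a stronger inhibitor, a higher number a weaker inhibitor:
- compound 1 `Cn1ncc(Cl)c1-c1cc(C(=O)N[C@@H]2CN[C@H](CC(N)=O)C[C@H]2c2ccc(Cl)c(Cl)c2)oc1Cl`: 160 nM
- compound 2 `CNC(=O)C[C@@H]1C[C@@H](c2ccc(F)c(F)c2)[C@H](NC(=O)c2cc(-c3c(Cl)cnn3C)c(Cl)o2)CN1`: 50 nM

Of these two, compound 1 has the higher number and is therefore the weaker inhibitor. The gap to compound 2 lies beyond the usual scatter of repeated measurements. The two compounds differ in more than one place, so their gap says nothing about any single change.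

Compound 3 `Cn1ncc(Cl)c1-c1cc(C(=O)N[C@@H]2CN[C@H](CCO)C[C@H]2c2ccc(Cl)c(Cl)c2)oc1Cl` is compound 1 with one alteration: hydroxymethyl in place of carbamoyl on a saturated chain carbon bound to a saturated ring carbon. In words, hydroxymethyl stands in place of carbamoyl on a saturated chain carbon bound to a saturated ring carbon. The side chain thus goes from carbamoylmethyl to 2-hydroxyethyl.

Among the measured compounds shown here, no measured pair shows this swap, so the expectation starts from compound 1 at 160 nM, with no direction favoured. The expected step in this assay, a 1.1-fold lower number from compound 1 to compound 3 (0.03 log units; within the scatter), is estimated to stay within the scatter. Compound 3 is estimated at 150 nM, with an expected range from 60 nM to 380 nM.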

Compound 3, half-maximal inhibitory concentration: 160 nM
For compound 3 the middle estimate is 1.1-fold (0.03 log units) below the measured one, within the range that was stated.
By their numbers in this assay, from the lowest: compound 2; then compounds 1 and 3 (each within the scatter of the next).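

In this assay, hydroxymethyl in place of carbamoyl gives no change at the digits printed from compound 1 to compound 3 (within the scatter), and this is the only comparison among the compounds shown that isolates a single change. At this saturated chain carbon bound to a saturated ring carbon, the carbamoylmethyl side chain can therefore be exchanged for 2-hydroxyethyl with no readable effect on the number, even though the exchange removes the nitrogen and the double bond of the carbamoyl group. No measurement shown here bears on why these two side chains read alike. As far as these compounds go, whether an amine, a carboxylic acid or a longer chain at this place would also match compound 1 in this assay remains open. Also open, from the compounds shown here alone, is whether the same exchange would read alike on compound 2, which differs from compound 1 in more than one place.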